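A few compounds are considered here, and "the series" means these few. Any claim that something is new, unique, unknown or untested is made for them only; others in the source may bear on it.

Compound 1 `COc1ccc2[nH]c(=O)c(-c3nc4cc(F)ccc4[nH]3)cc2c1`, compound 2 `COc1ccc2[nH]c(=O)c(-c3nc4cc(Cl)ccc4[nH]3)cc2c1`, compound 3 `Cc1ccc2[nH]c(=O)c(-c3nc4cc(F)ccc4[nH]3)cc2c1`.

In a functional assay on NCI-H460 cells (Homo sapiens) for cytotoxicity, read by MTT assay, with a stated time of 48 h (a lower number here means a stronger inhibitor, a higher number a weaker inhibitor), compound 1 gives only a limit, > 100000 nM. Compound 2 likewise reaches only a limit in this assay, > 100000 nM. Compound 3 also stops at a limit in this assay, > 100000 nM. All three sit at the limit of > 100000 nM in this assay, at which 3 of the 3 values shown sit, so no number is known for any of them.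

The change from compound 1 to compound 2 is chloro in place of fluoro on an aromatic carbon, and its step is a step that the two limits leave unreadable from compound 1 to compound 2. The change from compound 1 to compound 3 is methyl in place of methoxy on an aromatic carbon, with the step that the two limits leave unreadable from compound 1 to compound 3. Compound 4 `Cc1ccc2[nH]c(=O)c(-c3nc4cc(Cl)ccc4[nH]3)cc2c1` is not yet measured; it differs from compound 3 by chloro in place of fluoro on an aromatic carbon, the same change as that from compound 1 to compound 2, made on the core of compound 3 rather than on that of compound 1.

The expected step from compound 3 to compound 4 is a number no higher from compound 3 to compound 4 (the limit leaves the size open), which rests on compound 1 and compound 2 both lying at the limit of > 100000 nM in this assay, at which 3 of the 3 values shown sit. Compound 4 is therefore estimated at 100000 nM, most likely again only a limit.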

Compound 4, half-maximal inhibitory concentration: 36500 nM
For compound 4 the middle estimate is 2.7-fold (0.44 log units) above the measured one; measured number below the stated range.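

In this assay, chloro in place of fluoro on the core of compound 3 gives an at least 2.7-fold lower number from compound 3 to compound 4 (0.43 log units; beyond the scatter), and methyl in place of methoxy with chloro kept gives an at least 2.7-fold lower number from compound 2 to compound 4 (0.43 log units; beyond the scatter). The same chloro-for-fluoro change on the core of compound 1 cannot be read, nor can the methyl-for-methoxy change between compound 1 and compound 3, so the data do not show whether either change carries from one core to the other or whether the gain appears only when methyl and chloro occur together. The two readable steps give only minimum sizes, and their true sizes stay unknown because each starts from a compound that gives only a limit: the limit of > 100000 nM in this assay, at which 3 of the 4 values shown sit.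

Only compound 4 gives a number here, so the pattern rests on a single compound. On these data alone, whether an amine, a carboxylic acid or a longer chain in place of methyl would lower the number further in this assay remains open.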